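The source may report more compounds than this note shows. Statements on the series, on what has been measured and on what is new or still open speak of the compounds shown alone.

Measured so far in a functional assay on KB cells (Homo sapiens) for inhibition; on this read-out higher numbers stand for weaker inhibition and lower numbers for stronger inhibition:

compound 1, `CN(C)c1nc2cc(Cl)c(Cl)cc2n1COCCO`: > 100000 nM — a limit of the assay, not a number
compound 2, `CNc1nc2c(Cl)c(Cl)ccc2n1COCCO`: > 100000 nM — likewise a limit, not a number
compound 3, `OCCOCn1c(SCc2ccccc2)nc2c(Cl)c(Cl)ccc21`: 35000 nM

Going by the values given here, compound 3 thus holds the only actual number in this assay; the two other results sit at the limit of > 100000 nM in this assay, at which 2 of the 3 values shown sit, and say nothing more precise. Among the compounds with values here, the single measured step, an at least 2.8-fold lower number from compound 2 to compound 3 (0.45 log units; beyond the scatter), is benzylsulfanyl in place of methylamino on an aromatic carbon and leaves the limit for a number.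

Compound 4, `OCCOCn1c(S)nc2c(Cl)c(Cl)ccc21`, differs from compound 3 by hydrogen in place of benzyl on a sulfur. Within the data shown here, no measured step covers this removal; the step of an at least 2.8-fold lower number from compound 2 to compound 3 (0.45 log units; beyond the scatter) is the nearest, since it is the one in which the benzylsulfanyl group entered and the number fell, so taking the benzyl off again is expected to undo at least part of that gain. The step from compound 3 to compound 4 is therefore expected to be a 2.3-fold higher number from compound 3 to compound 4 (0.36 log units; beyond the scatter), towards weaker inhibition. Compound 4 is estimated at 80000 nM, between 25000 nM and 250000 nM, with a fair chance that this assay reports only a limit.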

Compound 4, half-maximal inhibitory concentration: > 100000 nM
Compound 4: a limit, no number; the forecaster's own chance of this, stated with the estimate: 50%; middle value at least 1.2-fold (0.09 log units) away from the limit.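

In this assay, hydrogen in place of benzyl on a sulfur gives an at least 2.8-fold higher number from compound 3 to compound 4 (0.45 log units; beyond the scatter), so the sulfur alone does not keep the measurable number of compound 3, and the benzyl is needed for it on the shared core. The step from compound 2 to compound 4 cannot be read, as both results are limits of the assay and not numbers. Compound 4 therefore joins the other limit results: the limit of > 100000 nM in this assay, at which 3 of the 4 values shown sit.

From the compounds shown here alone, whether the six-membered aromatic ring of the benzyl or only a carbon group on the sulfur counts stays open; a methyl or a longer alkyl chain on the sulfur would separate the two. Also open, going by these compounds, is whether the sulfur itself matters, which a benzylamino group on the same aromatic carbon would test.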